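Swapping a triazole-bearing arm for a styryl-like arm

A few compounds are considered here, and "the series" means these few. Any claim that something is new, unique, unknown or untested is made for them only; others in the source may bear on it.

Of the compounds shown here, three built on the same core have been tested in a functional assay on MCF7 cells (Homo sapiens) for cytotoxicity, read by MTT assay, with a stated time of 72 h; on this read-out lower numbers stand for stronger inhibition and higher numbers for weaker inhibition. Compound 1 `NS(=O)(=O)c1cc(-c2nnc(CN3CCN(c4ccc(Cl)cc4)CC3)o2)c(Cl)cc1SCc1ccccc1` gives 280000 nM. Within the data shown here, compound 2 `Cc1ccc(C)c(N2CCN(Cc3nnc(-c4cc(S(N)(=O)=O)c(SCc5ccccc5)cc4Cl)o3)CC2)c1` gives 51000 nM, and the single change in a 5.5-fold lower number from compound 1 to compound 2 (0.74 log units; beyond the scatter) is the only measured step. Compound 3 `CC(C)(O)c1cn(Cc2nnc(-c3cc(S(N)(=O)=O)c(SCc4ccccc4)cc3Cl)o2)nn1` gives 168000 nM, which places it second highest of the three numbers: the gap to compound 1 lies within the scatter, while the gap to compound 2 lies beyond it.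

Compound 4 `NS(=O)(=O)c1cc(-c2nnc(/C=C/c3c(Cl)cccc3Cl)o2)c(Cl)cc1SCc1ccccc1` differs from compound 3 in one place: 2-(2,6-dichlorophenyl)ethenyl in place of (4-(1-hydroxy-1-methylethyl)-1H-1,2,3-triazol-1-yl)methyl on an aromatic carbon. Among the measured compounds shown here, no measured step touches this position, so the step from compound 1 to compound 2, which alters a group on an amine nitrogen in a ring, offers only a sense of how much this series moves with one replacement. With so little to go on, compound 4 is expected to sit near the middle of the range seen so far, at 100000 nM with a range from 30000 nM to 330000 nM. That estimate means a step of a 1.7-fold lower number from compound 3 to compound 4 (0.23 log units; within the scatter), expected but uncertain.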

Compound 4, half-maximal inhibitory concentration: 29000 nM
Estimate against measurement, compound 4: 3.4-fold (0.54 log units) above; measured number outside the range, below it.
By their numbers in this assay, from the lowest: compounds 4 and 2 (each within the scatter of the next); then compounds 3 and 1 (each within the scatter of the next).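

In this assay, among these compounds, this carbon of the five-membered aromatic ring proves sensitive to replacement: the change gives a 5.8-fold lower number from compound 3 to compound 4 (0.76 log units; beyond the scatter), the first measured step at this position. The two groups hold the same number of heavy atoms, so that count does not separate them; instead, a triazole ring carrying a hydrogen-bond donor and acceptors gives way to a carbon-only aromatic ring with two chlorines, joined through a double bond. No supporting measurement explains why the number falls.

Since several features change in this one swap, the compounds shown leave open whether the double bond, the chlorines or the loss of the triazole accounts for the step. A 2-phenylethenyl group without chlorine, compared directly with compound 4, would test the part played by the two chlorines.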